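The source may report more compounds than this note shows. Statements on the series, on what has been measured and on what is new or still open speak of the compounds shown alone.

Measured so far:
compound 1 `CCOc1cccc2cc(-c3ccc(Br)cc3)c(=O)oc12` in an assay on CHO cells for displacement of a labelled ligand from adenosine receptor A1 (Homo sapiens), read by radioligand binding; a lower number here means a stronger inhibitor, a higher number a weaker inhibitor: > 100000 nM
compound 2 `CCOc1cccc2cc(-c3ccc(OC)cc3)c(=O)oc12` in this assay: > 100000 nM

Compound 2 stands at a limit of this assay, not at a number, with > 100000 nM. Compound 1 likewise gives only a limit, > 100000 nM. For the measured compounds named here, the one step measured, a step that the two limits leave unreadable from compound 1 to compound 2, cannot be read because the limit of > 100000 nM in this assay, at which 2 of the 2 values shown sit, holds both values. Compound 3 `CCOc1cccc2cc(-c3ccc([N+](=O)[O-])cc3)c(=O)oc12` carries the change (nitro in place of methoxy on an aromatic carbon), para to a large group on the six-membered carbon ring. Going by the values given here, no measured step reads on this change, and neither measured compound shows binding within the range of this assay. Compound 3 is therefore expected to remain at the limit as well, the estimated step that the limit leaves unreadable from compound 2 to compound 3 meaning no readable change. The estimate for compound 3 in this assay is 150000 nM, with a range from 30000 nM to 1000000 nM, most likely reported only as a limit.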

Compound 3, inhibition constant: > 100000 nM
Compound 3 gave a limit, no number; the forecaster's own chance of this, stated with the estimate: 85%; the middle value does not contradict the limit.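

For the compounds shown here, compound 3 gives only a limit in this assay, as do compound 1 and compound 2, so no step among compound 1, compound 2 and compound 3 can be read: the limit of > 100000 nM in this assay, at which 3 of the 3 values shown sit. The compounds shown leave open which change to the shared core, if any, would give a measurable value in this assay.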